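Branching the sulfonyl side chain of compound 1

A few compounds are considered here, and "the series" means these few. Any claim that something is new, unique, unknown or untested is made for them only; others in the source may bear on it.

Among the measured compounds shown here, in a physicochemical assay for lipophilicity (a higher number here means a more lipophilic compound, a lower number a more polar compound), compound 1 `CNCC(=O)Nc1ccc(-c2nc(CS(C)(=O)=O)cc([C@@]34CCOC[C@@H]3C4)n2)cc1` gives 3.1 and is the lowest of the three numbers measured so far. Compound 2 `Oc1cccc(-c2nccc([C@@]34CCOC[C@@H]3C4)n2)c1` gives 4 and compound 3 `Oc1cccc(-c2nccc([C@]34CCOC[C@H]3C4)n2)c1` gives 4 and both stand beyond the scatter from compound 1. Compound 4 `CNCC(=O)Nc1ccc(-c2nc(C(C)(C)S(C)(=O)=O)cc([C@@]34CCOC[C@@H]3C4)n2)cc1` awaits measurement and carries 1-methyl-1-(methylsulfonyl)ethyl in place of (methylsulfonyl)methyl on an aromatic carbon of the shared core. For the measured compounds named here, the only measured step of no change at the digits printed from compound 2 to compound 3 (within the scatter) joins mirror images the fact that compounds 2 and 3 differ only in the configuration as drawn and offers no guide to this change. With more carbon entering and the hydrogen-bond counts unchanged, a modest rise in this assay is expected and is estimated as a number 0.60 log units higher from compound 1 to compound 4 (beyond the scatter) on judgement alone. Compound 4 is therefore expected at 3.7 within a range from 3.3 to 4.1.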

Compound 4, partition coefficient: 4.3
Compound 4: middle estimate off by 0.60 log units, on the low side; the measured number lies above the stated range.
By their numbers in this assay, from the lowest: compound 1; then compounds 2, 3 and 4 (each within the scatter of the next).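

In this assay, putting 1-methyl-1-(methylsulfonyl)ethyl in place of (methylsulfonyl)methyl gives a large step, a number 1.20 log units higher from compound 1 to compound 4 (beyond the scatter). Among the compounds shown here, this is the only measured change at this aromatic carbon, and it shows that this side chain can move the number well beyond the scatter while the hydrogen-bond donor and acceptor counts stay the same. Nothing available bears on why the step has this size.

Going by these compounds, what 1-(methylsulfonyl)ethyl, an amine or a carboxylic acid would give on the same carbon in this assay remains open. So does whether this change would give a step of similar size on another compound.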